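Chain length on the urea nitrogen: compound 3 to compound 4

The compounds below may be only part of what the source reports. "The series", "measured", "known", "first", "only" and "open" are said of these compounds alone.

The series shares the core of compound 1 `CNC(=S)NCCC(O)c1cc(OC)ccc1N` and varies the group on the amine nitrogen. In an assay for inhibition of Nitric oxide synthase, inducible (Homo sapiens), read by scintillation counting, with a stated time of 30 min, tested at 1 mM (a higher number here means more inhibition at the concentration tested (going by the name of the read-out), a lower number less inhibition), compound 1 gives 76.6%. Compound 2 `CCCNC(=S)NCCC(O)c1cc(OC)ccc1N` gives 25.4% in this assay, and compound 3 `CCNC(=O)NCCC(O)c1cc(OC)ccc1N` gives 26.6%. Compound 3 thus lies far below compound 1, with a number 50 percentage points lower from compound 1 to compound 3 (beyond the scatter), and its nearest number is that of compound 2, with a number 1.2 percentage points higher from compound 2 to compound 3 (within the scatter).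

Compound 4 `CCCNC(=O)NCCC(O)c1cc(OC)ccc1N` differs from compound 3 by methyl in place of hydrogen on a saturated chain carbon, two bonds along the chain from an amide-type nitrogen. For the measured compounds named here, no measured step is an ethyl to propyl change on the urea itself. The related chain lengthening on the thiourea, a number 51.2 percentage points lower from compound 1 to compound 2 (beyond the scatter), was large, but it ran from methyl to propyl and started from a high number. From the low number of compound 3, and with compound 2 and compound 3 within scatter of each other, the step of a number 6.6 percentage points lower from compound 3 to compound 4 (within the scatter) expected in this assay is none beyond the scatter, leaning downward. Compound 4 is estimated at 20%, within 5% to 38%.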

Compound 4, a percentage reported as inhibition, at one concentration (the size of the read-out at that concentration, not a potency): 14.7%
For compound 4 the middle estimate is 5.3 percentage points above the measured one, and the stated range covers the measured number.
By their numbers in this assay, from the lowest: compound 4; then compounds 2 and 3 (each within the scatter of the next); then compound 1.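

In this assay, lengthening ethyl to propyl on the urea nitrogen has a measurable effect even from an already low number, a number 11.9 percentage points lower from compound 3 to compound 4 (beyond the scatter), and the same propyl group separates the urea from the thiourea, a number 10.7 percentage points lower from compound 2 to compound 4 (beyond the scatter); both steps are modest but beyond the scatter. The widest gap now stands at a number 61.9 percentage points lower from compound 1 to compound 4 (beyond the scatter), but that step changes the chain and the thiourea together, so it assigns no share to either.

A urea carrying methyl would separate those two contributions, and a longer chain such as butyl would show whether the downward step continues past propyl. As far as these compounds go, a terminal amine or carboxylic acid on the chain also remains open. Nothing on hand gives a cause for these steps.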